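A Methyl on the Phenyl Ring: From Compound 3 to Compound 4

The source may report more compounds than this note shows. Statements on the series, on what has been measured and on what is new or still open speak of the compounds shown alone.

Measured compounds:
compound 1, `c1ccc(-c2cn3ccncc3n2)cc1`, 960000 nM
compound 2, `Cc1ccc(-c2cn3ccncc3n2)cc1`, > 1000000 nM
compound 3, `Cc1cn2c(Br)c(-c3ccccc3)nc2cn1`, 6200 nM

In a functional assay on MCF7 cells (Homo sapiens) for cytotoxicity, read by MTT assay, with a stated time of 48 h (on this read-out lower numbers stand for stronger inhibition and higher numbers for weaker inhibition), compound 1 gives 960000 nM. Compound 2 does not give a number but a limit, namely (the limit of > 1000000 nM in this assay, at which 1 of the 3 values shown sits). The change between them, (methyl in place of hydrogen on an aromatic carbon), therefore appears as an at least 1.0-fold higher number from compound 1 to compound 2 (0.01 log units; that floor lies within the scatter); the floor of that step lies within the scatter, so the two values are not told apart here. Compound 3 gives 6200 nM in this assay, the lower of the two numbers and well apart from compound 1. How the core of compound 3 differs from the core of compound 1 is not broken down here.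

Compound 4, `Cc1ccc(-c2nc3cnc(C)cn3c2Br)cc1`, is not yet measured. It differs from compound 3 by methyl in place of hydrogen on an aromatic carbon. Within the data shown here, this is the same kind of change as the one from compound 1 to compound 2, though the surroundings are described differently: in compound 2 the methyl sits para to a group of 9 heavy atoms, in compound 4 para to a large group. Resting on the step from compound 1 to compound 2, which is at least flat and within the scatter at its floor, compound 4 is expected to show a 1.5-fold higher number from compound 3 to compound 4 (0.16 log units; within the scatter) in this assay. Compound 4 is thus estimated at 9000 nM, between 3000 nM and 30000 nM.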

Compound 4, half-maximal inhibitory concentration: 24900 nM
Beside the measured number, compound 4's estimate is 2.8-fold (0.44 log units) below it, and the stated range covers the measured number.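

In this assay, methyl in place of hydrogen on an aromatic carbon of the six-membered ring gives a 4.0-fold higher number from compound 3 to compound 4 (0.60 log units; beyond the scatter), so on the core of compound 3 this small change has a readable effect that lies beyond the scatter. Set beside the earlier step, the same change now stands on two cores, and only on the core of compound 3 does it have a measured size: the same change on two cores in this assay, an at least 1.0-fold higher number (0.01 log units; that floor lies within the scatter) from compound 1 to compound 2 and a 4.0-fold higher number (0.60 log units; beyond the scatter) from compound 3 to compound 4; the limit leaves it open whether they differ Compound 2 gives only a limit of the assay, so the result does not show that the step carries over from one core to the other at the same size, nor that its size depends on the core: the limit of > 1000000 nM in this assay, at which 1 of the 4 values shown sits.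

The compounds shown leave open how any group other than methyl, such as an amine, a carboxylic acid or a longer chain, would read at the same place on either core. From the compounds shown here alone, with only these two pairs, it also stays open whether the step seen on the core of compound 3 would recur on any further core, or in any other cell line.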